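The source may report more compounds than this note shows. Statements on the series, on what has been measured and on what is new or still open speak of the compounds shown alone.

Measured so far:
compound 1 `COc1ccc(CN2CCC=C(CCC(=O)NO)C2=O)cc1` — 6890 nM
compound 2 `Cc1ccc(CN2CCC=C(CCC(=O)NO)C2=O)cc1` — 8510 nM

Among the compounds with values here, of the two numbers in a functional assay on HCT-15 cells (Homo sapiens) for inhibition, read by sulforhodamine B assay (a higher number here means a weaker inhibitor of growth, a lower number a stronger inhibitor of growth), compound 2 gives the highest, with compound 1 nearest; the only step to it, a 1.2-fold higher number from compound 1 to compound 2 (0.09 log units; within the scatter), lies within the scatter.

Compound 3 `O=C(CCC1=CCCN(Cc2ccc(NC(=O)c3ccccc3)cc2)C1=O)NO` has not yet been measured in this assay. Its change from compound 2 is benzamido in place of methyl on an aromatic carbon. Within the data shown here, no measured step concerns a group of this kind: the single step, a 1.2-fold higher number from compound 1 to compound 2 (0.09 log units; within the scatter), swaps one small group for another and was within the scatter, so it offers little guidance for a benzamido entering. The expectation therefore rests mainly on compound 2 at 8510 nM, with a wide range to cover the unknown. For compound 3 the expected result is 4500 nM, between 1200 nM and 17000 nM. This estimate implies the step of a 1.9-fold lower number from compound 2 to compound 3 (0.28 log units; within the scatter), expected to lean toward a lower number but not clearly beyond the scatter.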

Compound 3, concentration for 50% growth inhibition: > 10000 nM
Compound 3: no number, only a limit; the forecaster's own chance of this, stated with the estimate: 5%; middle value at least 2.2-fold (0.34 log units) away from the limit.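

In this assay compound 3 gives > 10000 nM, which is a limit of the assay and not a number. A benzamido on this aromatic carbon, para to a large group, brings an added six-membered aromatic ring of carbon only, yet it gives no lower number than the small groups, with floors of an at least 1.1-fold higher number from compound 2 to compound 3 (0.07 log units; that floor lies within the scatter) and an at least 1.4-fold higher number from compound 1 to compound 3 (0.16 log units; that floor lies within the scatter). Both floors allow for little or much loss, so the true size of this change remains unresolved: the limit of > 10000 nM in this assay, at which 1 of the 3 values shown sits.

Open, going by these compounds, is whether the amide link or the added ring sets this outcome, which an amine or an acetamido on the same aromatic carbon could help separate. Also open, on these data alone, is whether any group at this place gives a number clearly beyond the scatter from compound 1 and compound 2.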